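The source may report more compounds than this note shows. Statements on the series, on what has been measured and on what is new or still open speak of the compounds shown alone.

Measured so far:
- compound 1, `CCCCCCCCCCCCCC[C@@H](O)[C@@H](O)[C@H](CO)n1cc(CCCCCC)nn1`: in a functional assay on K562 cells (Homo sapiens) for cytotoxicity, read by MTT assay (on this read-out higher numbers stand for an effect only at larger amounts of compound and lower numbers for an effect already at smaller amounts), compound 1 gives 12600 nM
- compound 2, `CCCCCCCCCCCCC/C=C/[C@@H](O)[C@H](CO)n1cc(CCCCCCCCCCCCC)nn1`: compound 2 reaches only the limit > 50000 nM
- compound 3, `CCCCCCCCCCCCC/C=C/[C@@H](O)[C@H](CO)n1cc(CCCCCC)nn1`: compound 3 gives 8200 nM

Compound 1 and compound 3 do not share a core that is broken down here; how the two cores differ is not counted. Their values in this assay sit close together, and the gap between compound 1 and compound 3 is within the usual scatter, so no order between them is claimed.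

The value of compound 2 is a limit of this assay and not a number. The step from compound 3 to compound 2 is an at least 6.0-fold higher number from compound 3 to compound 2 (0.78 log units; beyond the scatter); it can be given only as a lower bound because of the limit of > 50000 nM in this assay, at which 1 of the 3 values shown sits. The change behind it is heptyl in place of hydrogen on a saturated chain carbon, six bonds along the chain from an aromatic carbon.

Compound 4, `CCCCCCCCCCCCCC[C@@H](O)[C@@H](O)[C@H](CO)n1cc(CCCCCCCCCCCCC)nn1`, has not yet been measured. Among the measured compounds shown here, it arises from compound 1 by heptyl in place of hydrogen on a saturated chain carbon, six bonds along the chain from an aromatic carbon, the same change, at the same place, as the one from compound 3 to compound 2. For the measured compounds named here, since the change is identical in kind and position, the step from compound 1 to compound 4 is expected to resemble the one from compound 3 to compound 2, that is a 6.3-fold higher number from compound 1 to compound 4 (0.80 log units; beyond the scatter). Compound 1 starts at 12600 nM. Starting from there, the expected result would lie past what this assay reports as a number, so compound 4 is expected to be reported only as a limit. The estimate for compound 4 is 80000 nM, within a range from 30000 nM to 250000 nM, most likely reported only as a limit.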

Compound 4, half-maximal effective concentration: > 50000 nM
Compound 4 ended at the assay's limit; the forecaster's own chance of this, stated with the estimate: 70%; the middle value lies beyond the limit too.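

In this assay, putting heptyl in place of hydrogen on a saturated chain carbon, six bonds along the chain from an aromatic carbon, gives an at least 3.9-fold higher number from compound 1 to compound 4 (0.59 log units; beyond the scatter). This step is beyond the usual scatter, and so is the earlier one, so in these two pairs the change moves the number the same way on both cores, although two pairs are too few to make a rule for the series: the same change on two cores in this assay, an at least 6.0-fold higher number (0.78 log units; beyond the scatter) from compound 3 to compound 2 and an at least 3.9-fold higher number (0.59 log units; beyond the scatter) from compound 1 to compound 4; the limit leaves it open whether they differ. What this does not show is that the change has the same size on each core, since compound 2 and compound 4 both end at a limit and each step is only a lower bound, because the true numbers lie out of the assay's reach: the limit of > 50000 nM in this assay, at which 2 of the 4 values shown sit.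

The compounds shown leave open whether a shorter addition than heptyl, such as methyl or propyl, already raises the number, and whether the rise grows steadily with chain length or appears only past a certain length. They also leave open what a group of a different kind at the same place, such as an amine or a carboxylic acid, would do on either core.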